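A few compounds are considered here, and "the series" means these few. Any claim that something is new, unique, unknown or untested is made for them only; others in the source may bear on it.

In a functional assay on P388 cells (Mus musculus) for antiproliferative activity, read by colorimetric assay and MTT assay (on this read-out higher numbers stand for weaker inhibition and lower numbers for stronger inhibition), compound 1 `N#Cc1ccc(S(=O)(=O)Nc2cccc3c(Cl)c[nH]c23)cc1` gives 1.4 ug/mL and compound 2 `N#Cc1ccc(S(=O)(=O)Nc2ccc(Cl)c3cc[nH]c23)cc1` gives 1.8 ug/mL. These two numbers lie within the usual scatter of repeated measurements, so they cannot be ranked, and compound 2 stands level with compound 1 on this evidence. Compound 3 `N#Cc1ccc(S(=O)(=O)Nc2ccc(Cl)c3c(Cl)c[nH]c23)cc1` is compound 2 with one change, chloro in place of hydrogen on an aromatic carbon. Going by the values given here, no measured pair in this set shows what such a change does, so any expectation here is tentative. In this assay, a small shift towards stronger inhibition seems the likeliest outcome, with nothing clearly beyond the scatter. The expected step, a 1.6-fold lower number from compound 2 to compound 3 (0.21 log units; within the scatter), is therefore modest. For compound 3 the estimated value is 1.1 ug/mL, with an expected range of 0.4 ug/mL to 3 ug/mL.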

Compound 3, half-maximal inhibitory concentration: 0.59 ug/mL
Estimate against measurement, compound 3: 1.9-fold (0.27 log units) above, and the stated range covers the measured number.
By their numbers in this assay, from the lowest: compound 3; then compounds 1 and 2 (each within the scatter of the next).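

In this assay, chloro in place of hydrogen on an aromatic carbon of the five-membered aromatic ring, two ring bonds from the ring nitrogen, gives a 3.1-fold lower number from compound 2 to compound 3 (0.48 log units; beyond the scatter) and so shows a change at this position that can be read beyond the scatter. The other single change, chloro in place of hydrogen on a different aromatic carbon, gives a 2.4-fold lower number from compound 1 to compound 3 (0.38 log units; beyond the scatter) and points the same way, so here the two chloro groups together go with stronger inhibition than either one alone. No measurement shown here bears on the reason for these steps.

From the compounds shown here alone, whether a fluoro, a methyl or an amine at this position would give a similar step remains open. So does the size of this step on a core carrying no other chloro group.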